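A few compounds are considered here, and "the series" means these few. Any claim that something is new, unique, unknown or untested is made for them only; others in the source may bear on it.

Compound 1 `CCCC[C@H](CCn1cncn1)c1ccc(OC)cc1`, in an ADME assay on RD cells (Homo sapiens) for cytotoxicity, read by MTT assay, with a stated time of 3 days; a higher number here means that more compound is tolerated, a lower number that less compound is tolerated: 28.3 ug/mL
Compound 2 `CCCC[C@H](CCn1cncn1)c1ccc(C)cc1`, in this assay: 26.5 ug/mL

Compound 2 stands within the scatter of compound 1, the only other number shown, as a 1.1-fold lower number from compound 1 to compound 2 (0.03 log units; within the scatter) tells. Compound 3 `Cc1ccc([C@@H](CCn2cncn2)C2CCCCC2)cc1` differs from compound 2 at the side chain: cyclohexyl in place of butyl on a saturated chain carbon bound to an aromatic carbon and a saturated chain carbon. Among the measured compounds shown here, the one measured step changes a group on an aromatic carbon, not the chain, so no measured step bears on this change, and the data give no ground for a shift beyond the scatter. For compound 3 the expected step is a 1.1-fold lower number from compound 2 to compound 3 (0.03 log units; within the scatter), so compound 3 is estimated at 25 ug/mL, between 12 ug/mL and 50 ug/mL.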

Compound 3, half-maximal cytotoxic concentration: 57.9 ug/mL
Beside the measured number, compound 3's estimate is 2.3-fold (0.36 log units) below it, and the stated range ends below it.
By their numbers in this assay, from the lowest: compounds 2 and 1 (each within the scatter of the next); then compound 3.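

In this assay, the side chain position on the saturated chain carbon bound to an aromatic carbon and a saturated chain carbon responds where the aromatic group change did not: cyclohexyl in place of butyl gives a 2.2-fold higher number from compound 2 to compound 3 (0.34 log units; beyond the scatter). This single pair ties the modest step to a swap that brings in a ring and more carbon atoms. Nothing available explains the step.

Going by these compounds, whether the ring or the carbon count matters remains open; a hexyl chain or a cyclopentyl ring here would separate them. On these data alone, whether the step holds with methoxy on the aromatic carbon is also open.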